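The source may hold more compounds than are shown below. What is called first, only, known or untested is meant among the compounds shown, and "the series" means these compounds.

Working notes on the series. In an in vitro ADME assay on microsomes from liver (Homo sapiens) for metabolic stability, read by LC-MS, tested at 1 uM (a lower number here means slower removal, a higher number faster removal of the compound), compound 2 `CN(C)S(=O)(=O)c1ccc(F)c(C#Cc2cc(Cl)ccc2OCC(=O)O)c1` reads < 10 mL.min-1.g-1, which is a limit of the assay and not a number. It therefore gives a position at the limit, with no exact clearance to carry forward. Compound 3 `CCCS(=O)(=O)c1ccc(F)c(C#Cc2cc(Cl)ccc2OCC(=O)O)c1` has propyl in place of dimethylamino on a sulfonyl sulfur. The nearest measured reference is compound 1 `CCCS(=O)(=O)c1cccc(C#Cc2cc(Cl)ccc2OCC(=O)O)c1`, which also has propyl on its sulfonyl sulfur and differs elsewhere in the structure; compound 1 gives 11 mL.min-1.g-1. Among the measured compounds shown here, no measured pair isolates this change, so the expectation rests on that single value. In this assay a small upward move is expected, an at least 1.3-fold higher number from compound 2 to compound 3 (0.11 log units; that floor lies within the scatter), and it is not expected to stand clearly beyond the scatter. The estimated value for compound 3 is 13 mL.min-1.g-1, with an expected range from 10 mL.min-1.g-1 to 24 mL.min-1.g-1.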

Compound 3, intrinsic clearance in microsomes: 12 mL.min-1.g-1
For compound 3 the middle estimate is 1.1-fold (0.03 log units) above the measured one, and the stated range covers the measured number.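

Propyl in place of dimethylamino on a sulfonyl sulfur gives an at least 1.2-fold higher number from compound 2 to compound 3 (0.07 log units; that floor lies within the scatter) in this assay. The true size of this step stays open because compound 2 sits at a limit of the assay and not at a number: the limit of < 10 mL.min-1.g-1 in this assay, at which 1 of the 3 values shown sits.

Fluoro in place of hydrogen on an aromatic carbon, a change the earlier compounds did not isolate, gives a 1.1-fold higher number from compound 1 to compound 3 (0.04 log units; within the scatter) in this assay, so with propyl on the sulfonyl sulfur this step does not stand clear of the scatter.

As far as these compounds go, whether fluoro behaves the same way with dimethylamino on the sulfonyl sulfur remains open. Also open, from the compounds shown here alone, is how a longer chain or a cyclic amine on that sulfur would read in this assay.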